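Aryl carbamoyl-amino esters on a shared core: difluorophenyl step

The source may report more compounds than this note shows. Statements on the series, on what has been measured and on what is new or still open speak of the compounds shown alone.

Compound 1 `C=C[C@]1(C)C[C@@H](OC(=O)CNC(=O)Nc2ccccc2Br)[C@]2(C)[C@H](C)CC[C@]3(CCC(=O)[C@H]32)[C@@H](C)[C@@H]1O` carries a ((2-bromophenyl)carbamoyl)amino group on the shared core. In a functional assay on HGC-27 cells (Homo sapiens) for inhibition, read by MTT assay, with a stated time of 72 h (a lower number here means a stronger inhibitor, a higher number a weaker inhibitor), compound 1 gives only a limit, > 10000 nM, and not a number. Compound 2 `C=C[C@]1(C)C[C@@H](OC(=O)CNC(=O)NC(=O)c2ccc(Br)cc2)[C@]2(C)[C@H](C)CC[C@]3(CCC(=O)[C@H]32)[C@@H](C)[C@@H]1O` likewise stops at a limit in this assay, > 10000 nM. Compound 3 `C=C[C@]1(C)C[C@@H](OC(=O)CNC(=O)Nc2ccc(F)cc2)[C@]2(C)[C@H](C)CC[C@]3(CCC(=O)[C@H]32)[C@@H](C)[C@@H]1O` also records only a limit, > 10000 nM. The steps a step that the two limits leave unreadable from compound 1 to compound 2, a step that the two limits leave unreadable from compound 1 to compound 3 and a step that the two limits leave unreadable from compound 2 to compound 3 therefore cannot be sized, since all three values sit at the limit of > 10000 nM in this assay, at which 3 of the 3 values shown sit.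

Compound 4 `C=C[C@]1(C)C[C@@H](OC(=O)CNC(=O)Nc2ccc(F)cc2F)[C@]2(C)[C@H](C)CC[C@]3(CCC(=O)[C@H]32)[C@@H](C)[C@@H]1O` differs from compound 1 in one place: 2,4-difluorophenyl in place of 2-bromophenyl on an amide-type nitrogen. The measured steps that bear on an aryl exchange at this amide-type nitrogen, from compound 1 to compound 3 and from compound 1 to compound 2, are unreadable, so neither a direction nor a size beyond the scatter can be drawn from them. With every measured member of the series at the limit, compound 4 is expected to give 15000 nM, within 5000 nM to 50000 nM, most probably reported again as a limit. The corresponding estimated step that the limit leaves unreadable from compound 1 to compound 4 is expected to remain unreadable.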

Compound 4, half-maximal inhibitory concentration: > 10000 nM
Compound 4 ended at the assay's limit (the forecaster's own chance of this, stated with the estimate: 80%); the middle value does not contradict the limit.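

In this assay compound 4 gives > 10000 nM as a limit and not a number. Its steps from compound 1, compound 2 and compound 3 therefore cannot be read: the limit of > 10000 nM in this assay, at which 4 of the 4 values shown sit.

The compounds shown leave open whether any aryl group at this amide-type nitrogen reaches a measurable value in this assay at all.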